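The source may report more compounds than this note shows. Statements on the series, on what has been measured and on what is new or still open speak of the compounds shown alone.

Measured so far:
compound 1, `COc1cc(-c2cc(/C=C/C(=O)c3ccc(Cl)c(Cl)c3)[nH]n2)cc(OC)c1OC`, in a functional assay on CAKI-1 cells (Homo sapiens) for cytotoxicity, read by sulforhodamine B assay, with a stated time of 48 h, tested at 1 uM (a higher number here means a weaker effect of the compound at the concentration tested, a lower number a stronger effect), gives 87%
compound 2, `COc1ccc(C(=O)/C=C/c2cc(-c3cc(OC)c(OC)c(OC)c3)n[nH]2)cc1`, in this assay gives 89%

Compound 2 stands highest of the two numbers in this assay; the nearest is compound 1, and the step of a number 2 percentage points higher from compound 1 to compound 2 (within the scatter) lies within the scatter, so the two compounds cannot be told apart on these numbers. Compound 3, `COc1cc(-c2cc(/C=C/C(=O)c3ccc(F)c(F)c3)[nH]n2)cc(OC)c1OC`, remains to be measured in this assay. It differs from compound 2 in one place: 3,4-difluorophenyl in place of 4-methoxyphenyl on a carbonyl carbon. Within the data shown here, the only measured step that bears on this place is a number 2 percentage points higher from compound 1 to compound 2 (within the scatter), an exchange of the group on the same carbonyl carbon between 3,4-dichlorophenyl and 4-methoxyphenyl, which stayed within the scatter. The present change runs the other way, from 4-methoxyphenyl to 3,4-difluorophenyl. On this basis no step beyond the scatter is expected in this assay; the expected step is a number 2 percentage points lower from compound 2 to compound 3 (within the scatter). Compound 3 is estimated at 87%, with a range from 75% to 97%.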

Compound 3, a percentage reported as activity, at one concentration (the size of the read-out at that concentration, not a potency): 84%
Compound 3: middle estimate off by 3 percentage points, on the high side; low and high end bracket the measured number.
By their numbers in this assay, from the lowest: compounds 3, 1 and 2 (each within the scatter of the next).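

In this assay, 3,4-difluorophenyl on the carbonyl carbon gives a number 5 percentage points lower from compound 2 to compound 3 (within the scatter) and a number 3 percentage points lower from compound 1 to compound 3 (within the scatter). The place now holds three different groups, and exchanging 4-methoxyphenyl or 3,4-dichlorophenyl for 3,4-difluorophenyl leaves the compounds indistinguishable at the single concentration tested, so this read-out shows no preference among these three aryl groups. No measurement at hand accounts for this lack of separation.

From the compounds shown here alone, all three compounds carry a substituted phenyl on the carbonyl carbon, so it remains open whether a group of another kind there, such as a piperidine, a morpholine or a simple alkyl chain, would give a step beyond the scatter. The compounds shown also leave open whether changes elsewhere on the shared core would alter the read-out.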